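Compound 3: 3-(dimethylamino)propyl in place of 1-phenylethyl

The compounds below may be only part of what the source reports. "The series", "measured", "known", "first", "only" and "open" are said of these compounds alone.

In a functional assay on MDA-MB-435 cells (Homo sapiens) for cytotoxicity, read by MTT assay, with a stated time of 72 h (a lower number here means a stronger inhibitor, a higher number a weaker inhibitor), compound 1 `N[C@H]1CC[C@H](Nc2c(C(=O)NCc3ccc(F)cc3)nc(N3CCCCS3(=O)=O)c3cccnc23)CC1` gives 5000 nM as a measured number. Compound 2 `C[C@@H](Nc1c(C(=O)NCc2ccc(F)cc2)nc(Br)c2cccnc12)c1ccccc1` reads > 20000 nM as a limit of the assay and not a number. Compound 3 `CN(C)CCCNc1c(C(=O)NCc2ccc(F)cc2)nc(Br)c2cccnc12` carries the change 3-(dimethylamino)propyl in place of 1-phenylethyl on a nitrogen on an aromatic ring in the form of 3-(dimethylamino)propyl in place of 1-phenylethyl on a nitrogen on an aromatic ring. Going by the values given here, no measured step isolates this change, and the only reference number is compound 1 at 5000 nM in this series. A gain in potency is expected, with the step of an at least 3.3-fold lower number from compound 2 to compound 3 (0.52 log units; beyond the scatter) as the estimate. Compound 3 is estimated at 6000 nM within a range of 1500 nM to 20000 nM in this assay once measured.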

Compound 3, half-maximal inhibitory concentration: 7000 nM
Compound 3: the middle estimate sits 1.2-fold (0.07 log units) below what was measured; the measured number falls inside the stated range.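

In this assay, the nitrogen on an aromatic ring accepts an open chain with a terminal dimethylamino group: 3-(dimethylamino)propyl in place of 1-phenylethyl gives an at least 2.8-fold lower number from compound 2 to compound 3 (0.45 log units; beyond the scatter). Going by these compounds alone, this is the first step readable at this position. Its true size is bounded on one side only, since compound 2 stands at a limit of the assay and not a number: the limit of > 20000 nM in this assay, at which 1 of the 3 values shown sits.

The change removes the aromatic ring and brings in a nitrogen at once, and the compounds shown do not separate the two. An unsubstituted propyl chain, or a longer chain ending in a primary amine, would bear on that.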